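Side-chain variation on a weak topoisomerase series

This account rests on a few compounds, and the source may have more. Where it says the series, first, only, none or still open, it means among the compounds named here.

Measured compounds:
compound 1 `N[C@@H]1CCN(c2cc3c(cc2F)c(=O)c(C(=O)O)cn3Cc2ccc(-c3ccccc3)cc2)C1` with 63600 nM
compound 2 `O=C(O)c1cn(Cc2ccc(-c3ccccc3)cc2)c2cc(NC[C@@H]3CCNC3)c(F)cc2c1=O` with 104000 nM

Both values come from an assay on isolated protein for inhibition of DNA topoisomerase 1 (Homo sapiens), with a stated time of 15 min; on this read-out higher numbers stand for weaker inhibition and lower numbers for stronger inhibition. Compound 2 stands at the highest of the two numbers; the nearest is compound 1, and the step of a 1.6-fold higher number from compound 1 to compound 2 (0.21 log units; within the scatter) lies within the scatter, so no order between the two can be claimed. Among the compounds with values here, the only measured step, the exchange of the amine-bearing group on the aromatic carbon of the shared core, did not move this assay beyond the scatter.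

Compound 3 `NCCNc1cc2c(cc1F)c(=O)c(C(=O)O)cn2Cc1ccc(-c2ccccc2)cc1` carries the same core, the same biphenylmethyl group and the same (2-aminoethyl)amino attachment point as compound 2; the change is aminomethyl in place of pyrrolidin-3-yl on a saturated chain carbon bound to a nitrogen on an aromatic ring.

This is again a variation of the amine side chain, of the kind that from compound 1 to compound 2 produced only a step within the scatter. Nothing else among the measured steps bears on it. The expectation is therefore a step of a 1.0-fold lower number from compound 2 to compound 3 (0.02 log units; within the scatter) in this assay, that is, none beyond the scatter. Compound 3 is estimated at 100000 nM, with a range from 40000 nM to 250000 nM.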

Compound 3, half-maximal inhibitory concentration: 72800 nM
For compound 3 the middle estimate is 1.4-fold (0.14 log units) above the measured one, within the range that was stated.
By their numbers in this assay, from the lowest: compounds 1, 3 and 2 (each within the scatter of the next).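

Aminomethyl in place of pyrrolidin-3-yl on a saturated chain carbon bound to a nitrogen on an aromatic ring gives a 1.4-fold lower number from compound 2 to compound 3 (0.15 log units; within the scatter) in this assay and shows that, in this comparison, losing the ring and its defined stereocentre while going from 5 heavy atoms to 2 leaves the number within the scatter. The second comparison, (2-aminoethyl)amino in place of 3-aminopyrrolidin-1-yl on an aromatic carbon, gives a 1.1-fold higher number from compound 1 to compound 3 (0.06 log units; within the scatter) and so extends the same reading to a side chain with no ring, leaving compounds 1, 2 and 3 without any order in this assay and this position without a detectable preference among the three amine-bearing groups. No supporting measurement bears on this result, and nothing here gives a reason for it.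

Open, as far as these compounds go, is whether a side chain ending in a hydroxyl instead of an amine, or a longer chain such as 3-aminopropyl, would produce a step beyond the scatter at this position. Also open, from the compounds shown here alone, is whether a primary amide in place of the carboxylic acid, or hydrogen in place of the fluorine, would move these numbers on the shared core.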